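The source may report more compounds than this note shows. Statements on the series, on what has been measured and on what is new or still open speak of the compounds shown alone.

Measured so far in a functional assay on HeLa cells (Homo sapiens) for antiproliferative activity, read by MTT assay, with a stated time of 24 h; a higher number here means a weaker inhibitor, a lower number a stronger inhibitor:
- compound 1 `O=S(=O)(c1ccccc1)n1c(-c2cn(-c3ccccc3)nc2-c2ccc(C(F)(F)F)cc2)nc2ccccc21`: 560 nM
- compound 2 `Cc1ccc(C)c(S(=O)(=O)n2c(-c3cn(-c4ccccc4)nc3-c3ccc(C(F)(F)F)cc3)nc3ccccc32)c1`: 210 nM

Compound 2, at 210 nM, holds the lower of the two numbers in this assay. Compound 3 `O=S(=O)(c1ccc(Cl)cc1)n1c(-c2cn(-c3ccccc3)nc2-c2ccc(C(F)(F)F)cc2)nc2ccccc21` carries 4-chlorophenyl in place of 2,5-dimethylphenyl on a sulfonyl sulfur. Among the measured compounds shown here, only one measured step bears on this change, the modest 2.7-fold lower number from compound 1 to compound 2 (0.43 log units; beyond the scatter), which installed 2,5-dimethylphenyl in place of phenyl. For the measured compounds named here, no measured compound yet carries 4-chlorophenyl, so a modest rise that gives back part of that step is expected. The expected change is a 1.7-fold higher number from compound 2 to compound 3 (0.22 log units; within the scatter). For compound 3 the estimate is 350 nM, with an expected range of 130 nM to 900 nM.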

Compound 3, half-maximal inhibitory concentration: 3060 nM
The estimate for compound 3 lay 8.7-fold (0.94 log units) below the measured number; the measured number lies above the stated range.
By their numbers in this assay, from the lowest: compound 2; then compound 1; then compound 3.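

In this assay the ring on the sulfonyl sulfur turns out to move the number in either direction, not only down: the swap to 4-chlorophenyl gives a 15-fold higher number from compound 2 to compound 3 (1.16 log units; beyond the scatter) and is large, while chloro in place of hydrogen on an aromatic carbon gives a 5.5-fold higher number from compound 1 to compound 3 (0.74 log units; beyond the scatter) on its own. The plain phenyl of compound 1 therefore sits between compound 2 and compound 3. Nothing available explains this rise.

Still open, on these data alone, is whether a 4-methylphenyl, 4-methoxyphenyl or 4-fluorophenyl group on the sulfonyl sulfur would rise as compound 3 does or fall as compound 2 does.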